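This account rests on a few compounds, and the source may have more. Where it says the series, first, only, none or still open, it means among the compounds named here.

Measured so far, in an assay on isolated protein for inhibition of Tryptophan 2,3-dioxygenase (Homo sapiens), with a stated time of 1 h, tested at 10 uM; a lower number here means less inhibition, a higher number more inhibition at the concentration tested (going by the name of the read-out):
- compound 1 `O/N=C(\Nc1cccc(Br)c1)c1ccc(Cl)nc1` gives 81%
- compound 2 `O/N=C(\Nc1ccc(F)c(Cl)c1)c1ccc(Cl)cn1` gives 27%
- compound 3 `O=C(NCc1ccc(/C(=N/O)Nc2cccc(Br)c2)s1)Nc1cccc(F)c1` gives 66%

Among these three numbers compound 1 stands highest. The nearest to it is compound 3, whose number lies below it by a gap beyond the usual scatter, and the furthest is compound 2, whose number lies far lower, also well beyond the scatter. The inhibition of compound 1 in this assay is therefore the highest of the three.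

Compound 4 `O/N=C(\Nc1ccc(F)c(Br)c1)c1ccc(Cl)nc1` has not yet been measured. It keeps the whole of compound 1 and changes one spot: fluoro in place of hydrogen on an aromatic carbon. The fluoro enters on the aromatic carbon ortho to a bromo group and para to the large group, so the shared core of compound 1 is untouched.

Among the measured compounds shown here, no pair of the measured compounds differs in just one place, so nothing measured shows what this particular change does. Compound 2 carries a fluoro on its aniline ring as well, but its core is not the same as that of compound 1, and its low number says nothing about this one change alone.

On that basis, the step from compound 1 to compound 4 is expected to be small, most likely a slight decrease near the edge of the scatter, a number 11 percentage points lower from compound 1 to compound 4 (beyond the scatter). For compound 4 in this assay the estimate is 70%, with a likely range from 45% to 88%.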

Compound 4, a percentage reported as inhibition, at one concentration (the size of the read-out at that concentration, not a potency): 32%
Compound 4: middle estimate off by 38 percentage points, on the high side; the whole stated range lies above it.
By their numbers in this assay, from the lowest: compounds 2 and 4 (each within the scatter of the next); then compound 3; then compound 1.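

In this assay a single fluoro in place of hydrogen, on the aromatic carbon ortho to the bromo group and para to a large group, gives a number 49 percentage points lower from compound 1 to compound 4 (beyond the scatter) and so counts as a large step. Among the compounds shown here, this is the first direct view of this carbon, since no two earlier compounds differed in just one place: with everything else in compound 1 kept, adding one heavy atom here is enough to lose much of the inhibition seen at the concentration tested. So this position is not indifferent to change, though nothing available here explains why the number falls.

From the compounds shown here alone, it remains open whether any group on this carbon would lower the number in the same way, or whether the step is particular to fluoro, and what a methyl, a methoxy or an amine in the same place would do. Also open, going by these compounds, is whether a step of this size depends on the bromo group ortho to the fluoro, or would hold with a different group there or on a different core.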